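Methyl on the phenol oxygen of a sulfonamide imidazole

This account rests on a few compounds, and the source may have more. Where it says the series, first, only, none or still open, it means among the compounds named here.

Measured compounds:
Compound 1, `CN(c1cccc2c1CCCC2c1c[nH]cn1)S(C)(=O)=O`: 204 nM
Compound 2, `CS(=O)(=O)Nc1c(O)ccc2c1CCCC2c1c[nH]cn1`: 36.3 nM

Of the compounds shown here, two have been measured in an assay on isolated protein for binding affinity to Alpha-1A adrenergic receptor (Rattus norvegicus), read by radioligand binding; on this read-out higher numbers stand for weaker inhibition and lower numbers for stronger inhibition. Compound 1 gives 204 nM in this assay, and compound 2 gives 36.3 nM, the lower of the two numbers; the gap between them lies beyond the scatter, so compound 2 stands as the stronger binder of this pair. Compound 3, `COc1ccc2c(c1NS(C)(=O)=O)CCCC2c1c[nH]cn1`, differs from compound 2 by methyl in place of hydrogen on an oxygen on an aromatic ring. Going by the values given here, no measured pair shows this change on its own, so its effect is a matter of expectation, not of record. The step of a 3.0-fold higher number from compound 2 to compound 3 (0.48 log units; beyond the scatter) is expected to be a rise in the number, of modest size, and probably beyond the scatter rather than within it. Compound 3 is therefore estimated at 110 nM, with a range from 30 nM to 400 nM.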

Compound 3, inhibition constant: 501 nM
For compound 3 the middle estimate is 4.6-fold (0.66 log units) below the measured one; measured number above the stated range.
By their numbers in this assay, from the lowest: compound 2; then compound 1; then compound 3.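

Going from hydroxy to methoxy on the aromatic ring adds a single carbon, yet in this assay it gives a 14-fold higher number from compound 2 to compound 3 (1.14 log units; beyond the scatter), a large step. Going by these compounds alone, this is the first record of this change on its own, and it shows that binding at this oxygen is sensitive to even the smallest alkyl group, with weaker binding once methyl replaces the hydrogen. Nothing at hand accounts for the size of this step.

The compounds shown cannot say whether the loss is specific to methyl or would grow with a longer chain such as ethyl on the same oxygen. They also leave open how an amine or a fluorine in place of the hydroxy would read, and so whether the free hydroxy itself is needed.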